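The source may report more compounds than this note shows. Statements on the series, on what has been measured and on what is new or still open speak of the compounds shown alone.

In a functional assay on UACC-62 cells (Homo sapiens) (on this read-out lower numbers stand for stronger inhibition of growth and higher numbers for weaker inhibition of growth), compound 1 `O=S(=O)(/C=C/c1ccc(O)cc1)Cc1ccc(Nc2ncnc3ccccc23)cc1` gives 100000 nM. Compound 2 `O=S(=O)(/C=C/c1ccc(Br)cc1)Cc1ccc(Nc2ncnc3ccc(Br)cc23)cc1` gives > 100000 nM, which is a limit of the assay and not a number. Compound 2 therefore stands at the limit of > 100000 nM in this assay, at which 1 of the 2 values shown sits.

Compound 3 `O=S(=O)(/C=C/c1ccc(F)cc1F)Cc1ccc(Nc2ncnc3ccc(Br)cc23)cc1` keeps the rest of compound 2 and changes one group: 2,4-difluorophenyl takes the place of 4-bromophenyl on a double-bonded chain carbon bound to a double-bonded chain carbon. The count of that change reads (2,4-difluorophenyl in place of 4-bromophenyl on a double-bonded chain carbon bound to a double-bonded chain carbon). Among the compounds with values here, no two measured compounds differ in just one place, so no measured step shows what a swap like this does in this assay.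

Within the data shown here, the only numerical guide is compound 1 at 100000 nM, so a result near that level is expected. A limit may again be all that is reported for compound 3. The expected direction is toward slightly stronger inhibition of growth, but the estimated change an at least 1.2-fold lower number from compound 2 to compound 3 (0.09 log units; that floor lies within the scatter) is small and may not rise beyond the usual scatter. For compound 3 the estimated value is 80000 nM, with an expected range of 25000 nM to 100000 nM.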

Compound 3, concentration for 50% growth inhibition: 3000 nM
The estimate for compound 3 lay 27-fold (1.43 log units) above the measured number; the whole stated range lies above it.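

In this assay, within the data shown here, this is the first sign that the aryl group on a double-bonded chain carbon bound to a double-bonded chain carbon can decide growth inhibition: with the rest of the molecule unchanged, replacing 4-bromophenyl with 2,4-difluorophenyl gives an at least 33-fold lower number from compound 2 to compound 3 (1.52 log units; beyond the scatter). Compound 2 gives > 100000 nM, which is a limit of the assay and not a number. The step therefore sets only a minimum size, and the true change may be larger, since one end of the comparison is this limit: the limit of > 100000 nM in this assay, at which 1 of the 3 values shown sits.

The swap removes bromine and brings in two fluorines at once, so the compounds shown cannot tell whether the gain comes from losing the bromine, from adding fluorine, or from the particular 2,4-difluoro arrangement; comparisons with 4-fluorophenyl, 2-fluorophenyl or plain phenyl in this place would begin to separate these possibilities. Going by these compounds, it also remains open whether the gain would carry over to a core without its bromine, as in compound 1, and how a quite different group here, such as an aminophenyl or a carboxyphenyl, would behave.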